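The source may hold more compounds than are shown below. What is called first, only, known or untested is meant among the compounds shown, and "the series" means these compounds.

Measured in a functional assay on HL-60 cells (Homo sapiens) for antiproliferative activity, read by sulforhodamine B assay, with a stated time of 72 h; on this read-out higher numbers stand for weaker inhibition and lower numbers for stronger inhibition:

- Compound 1 `Fc1ccccc1NC(=S)N/N=C/c1ccc2ccccc2n1`: > 100000 nM (a limit)
- Compound 2 `S=C(N/N=C/c1ccc2ccccc2n1)Nc1ccc(Cl)cc1`: > 100000 nM (a limit)
- Compound 3 `S=C(N/N=C/c1ccc2ccccc2n1)Nc1ccccc1Br`: > 100000 nM (a limit)

Compound 3 stands at > 100000 nM, which is a limit and not a number. The same holds across the series, with the limit of > 100000 nM in this assay, at which 3 of the 3 values shown sit.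

The next compound is compound 4 `S=C(N/N=C/c1ccc2ccccc2n1)Nc1ccc(Br)cc1`. It keeps the core of compound 3 and changes one group: 4-bromophenyl in place of 2-bromophenyl on an amide-type nitrogen. In words, 4-bromophenyl takes the place of 2-bromophenyl on an amide-type nitrogen whose other neighbour is the thiocarbonyl carbon.

Within the data shown here, two measured steps bear most directly on this change: a step that the two limits leave unreadable from compound 2 to compound 3 and a step that the two limits leave unreadable from compound 1 to compound 3. Neither has a readable size, so they offer no direction for the change. Compound 2 already carries a 4-chlorophenyl group at this place and gives > 100000 nM, again a limit. In this assay, no step beyond the scatter is therefore expected, and the expected step is a number no higher from compound 3 to compound 4 (the limit leaves the size open). Compound 4 is estimated at 100000 nM, with an expected range of 30000 nM to 300000 nM.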

Compound 4, half-maximal inhibitory concentration: 27500 nM
For compound 4 the middle estimate is 3.6-fold (0.56 log units) above the measured one, outside the stated range (below it).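

In this assay, among these compounds, the group on the amide-type nitrogen now makes a readable difference for the first time: 4-bromophenyl in place of 2-bromophenyl gives an at least 3.6-fold lower number from compound 3 to compound 4 (0.56 log units; beyond the scatter). The 4-chlorophenyl group of compound 2 does not share this result, with the change to 4-bromophenyl giving an at least 3.6-fold lower number from compound 2 to compound 4 (0.56 log units; beyond the scatter), and 4-bromophenyl in place of 2-fluorophenyl gives an at least 3.6-fold lower number from compound 1 to compound 4 (0.56 log units; beyond the scatter). Compound 4 is thus the only compound shown with a number and not a limit, and the steps among the other three cannot be read: the limit of > 100000 nM in this assay, at which 3 of the 4 values shown sit.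

From the compounds shown here alone, the full size of each new step stays open, for one end of each is a limit. Also open, going by these compounds, is how a 4-iodophenyl, 4-methoxyphenyl or 4-aminophenyl group at this place would compare with 4-bromophenyl.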